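Aryl hydroxamate ureas: alkyl linker traded for a benzyl

A few compounds are considered here, and "the series" means these few. Any claim that something is new, unique, unknown or untested is made for them only; others in the source may bear on it.

Three compounds sharing the diaryl urea carry the hydroxamic acid on different tethers. Compound 1 `O=C(Nc1ccc2c(c1)CCN2c1ccc(C(=O)NO)cc1)Nc1ccc(Cl)c(C(F)(F)F)c1` gives 3400 nM in a functional assay on A549 cells (Homo sapiens) for inhibition, read by sulforhodamine B assay, with a stated time of 48 h; a higher number here means a weaker inhibitor, a lower number a stronger inhibitor. Compound 2 `O=C(Nc1ccc(C(=O)NO)cc1)Nc1ccc(Cl)c(C(F)(F)F)c1` gives 7200 nM in this assay. Compound 3 `O=C(CCCCCC(=O)Nc1ccc(NC(=O)Nc2ccc(Cl)c(C(F)(F)F)c2)cc1)NO` returns only a limit in this assay, > 10000 nM, so its true value is not known; this is the one case of the limit of > 10000 nM in this assay, at which 1 of the 3 values shown sits, among the three. Compound 3 thus stands at the weak end of the numbers shown, while compound 1 and compound 2 are within the scatter of each other.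

Compound 4 `O=C(Nc1ccc(NCc2ccc(C(=O)NO)cc2)cc1)Nc1ccc(Cl)c(C(F)(F)F)c1` is not yet measured. It differs from compound 3 by 4-(hydroxycarbamoyl)benzyl in place of (5-(hydroxycarbamoyl)pentyl)carbonyl on a nitrogen on an aromatic ring. The change brings the hydroxamic acid back onto an aromatic ring, as in compound 1 and compound 2, both of which give numbers rather than a limit. A step toward stronger inhibition, larger than the scatter, is therefore expected from compound 3 to compound 4, an at least 2.0-fold lower number from compound 3 to compound 4 (0.30 log units; that floor lies within the scatter). Compound 4 is estimated at 5000 nM, within 1500 nM to 15000 nM, in this assay.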

Compound 4, half-maximal inhibitory concentration: 4300 nM
Estimate against measurement, compound 4: 1.2-fold (0.07 log units) above, within the range that was stated.
By their numbers in this assay, from the lowest: compounds 1, 4 and 2 (each within the scatter of the next, the first and the last beyond it). At a limit, above all of these: compound 3.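

For the compounds shown here, at the nitrogen on an aromatic ring, 4-(hydroxycarbamoyl)benzyl in place of (5-(hydroxycarbamoyl)pentyl)carbonyl gives an at least 2.3-fold lower number from compound 3 to compound 4 (0.36 log units; beyond the scatter) in this assay, the first one-place comparison. Both groups count 11 heavy atoms, so this step comes with an open chain and its carbonyl giving way to a six-membered aromatic ring, not with added heavy atoms. Compound 3 is held at a limit, so the step is a floor and its full size is unknown: the limit of > 10000 nM in this assay, at which 1 of the 4 values shown sits.

Going by these compounds, whether the ring or the loss of the carbonyl on that nitrogen carries the step stays open, and a plain alkyl chain ending in the hydroxamic acid at the same place would separate the two. A carboxylic acid in place of the hydroxamic acid on the benzyl would show how much of the value of compound 4, 4300 nM, depends on that end group.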